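Hydroxy for fluoro on the sulfonyl-linked ring

The compounds below may be only part of what the source reports. "The series", "measured", "known", "first", "only" and "open" are said of these compounds alone.

Compound 1: `CC(O)(C(=O)Nc1ccc(S(=O)(=O)c2ccccc2F)cc1)C(F)(F)F`, 1300 nM
Compound 2: `CC(O)(C(=O)Nc1ccc(S(=O)(=O)c2ccccc2)c(C#N)c1)C(F)(F)F`, 3800 nM

Of the compounds shown here, two have been measured in a functional assay (Cavia porcellus) with sulfonylurea receptors; K-ATP channels (Homo sapiens) as the target; a higher number here means a weaker inhibitor, a lower number a stronger inhibitor. Compound 1 gives 1300 nM, the lowest of the two numbers; compound 2 gives 3800 nM, a higher number that lies beyond the scatter. Compound 3, `CC(O)(C(=O)Nc1ccc(S(=O)(=O)c2ccccc2O)cc1)C(F)(F)F`, is not yet measured. It differs from compound 1 by hydroxy in place of fluoro on an aromatic carbon. Among the measured compounds shown here, no measured pair shows this change, so its size is unknown. The account expects a step no larger than the scatter, a 1.4-fold higher number from compound 1 to compound 3 (0.14 log units; within the scatter), so that compound 3 is estimated at 1800 nM, within a range from 600 nM to 6000 nM.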

Compound 3, half-maximal inhibitory concentration: 3090 nM
Compound 3: the middle estimate sits 1.7-fold (0.23 log units) below what was measured; measured number inside the range.
By their numbers in this assay, from the lowest: compound 1; then compounds 3 and 2 (each within the scatter of the next).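

In this assay, among the compounds shown here, the change from 2-fluorophenyl to 2-hydroxyphenyl gives a 2.4-fold higher number from compound 1 to compound 3 (0.38 log units; beyond the scatter) and so provides the first reading at this position, a modest step. The place ortho to a large group is therefore not indifferent to its substituent, yet the hydroxy compound still gives a measurable inhibitory value. Nothing available explains this step. The compounds shown leave open whether methoxy or an amine at this place would match fluoro. They also leave open whether the same step would appear with a nitrile on the other ring.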